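From Compound 3 to Compound 4: One Added Methyl

The compounds below may be only part of what the source reports. "The series", "measured", "known", "first", "only" and "open" are said of these compounds alone.

In an ADME assay on microsomes from liver (Rattus norvegicus) for metabolic stability, read by LC-MS, using NADPH, with a stated time of 30 min, tested at 1 uM (on this read-out lower numbers stand for slow clearance and higher numbers for fast clearance), compound 1 `CC(C)[C@H]1COC(=O)N1c1ccnc(N[C@@H](C)c2ccc(-c3ccnc(C(F)(F)F)c3)cn2)n1` gives 101 mL.min-1.g-1 and compound 2 `CC(C)[C@H]1COC(=O)N1c1ccnc(N[C@@H](C)c2ccc(-c3ccnc(C(C)(C)C)c3)cn2)n1` gives 235 mL.min-1.g-1 as its number. Compound 3 `Cc1cc([C@H](C)Nc2nccc(N3C(=O)OC[C@@H]3C)n2)ncc1-c1ccnc(C(F)(F)F)c1` stands lowest of the three at 36 mL.min-1.g-1 on this scale. Compound 4 `CC[C@H]1COC(=O)N1c1ccnc(N[C@@H](C)c2cc(C)c(-c3ccnc(C(F)(F)F)c3)cn2)n1` departs from compound 3 by one change methyl in place of hydrogen on a saturated chain carbon bound to a saturated ring carbon on a saturated chain carbon bound to a saturated ring carbon, turning methyl to ethyl. Among the measured compounds shown here, no measured step covers this change directly. For the measured compounds named here, the only guide is a 2.3-fold higher number from compound 1 to compound 2 (0.37 log units; beyond the scatter), a modest rise beyond the scatter for a different change, tert-butyl in place of trifluoromethyl. A small upward move is therefore expected in this assay, with the estimated step being a 1.5-fold higher number from compound 3 to compound 4 (0.18 log units; within the scatter) overall. For compound 4 the estimated value is 55 mL.min-1.g-1, with an expected range of 30 mL.min-1.g-1 to 100 mL.min-1.g-1.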

Compound 4, intrinsic clearance in microsomes: 58 mL.min-1.g-1
Compound 4: middle estimate off by 1.1-fold (0.02 log units), on the low side; the measured number falls inside the stated range.
By their numbers in this assay, from the lowest: compounds 3, 4 and 1 (each within the scatter of the next, the first and the last beyond it); then compound 2.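

In this assay, a 1.6-fold higher number from compound 3 to compound 4 (0.21 log units; within the scatter) stays within the scatter, so turning 4-methyl-2-oxo-1,3-oxazolidin-3-yl into 4-ethyl-2-oxo-1,3-oxazolidin-3-yl leaves no readable shift. Among the compounds shown here, this is the first reading at this position, as the only earlier step, a 2.3-fold higher number from compound 1 to compound 2 (0.37 log units; beyond the scatter), concerned a different group and lay beyond the scatter. Nothing available explains this result.

Going by these compounds, whether a longer chain, a hydroxymethyl group or an amine on this saturated chain carbon would also stay within the scatter remains open. So does whether the added methyl would read the same with tert-butyl in place of trifluoromethyl.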